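Chlorine enters the phenoxy group of an EP2 agonist core

The source may report more compounds than this note shows. Statements on the series, on what has been measured and on what is new or still open speak of the compounds shown alone.

Of the compounds shown here, three that share one core have been measured in a functional assay on CHO cells for agonist activity at prostaglandin E2 receptor EP2 subtype (Homo sapiens), read by HTRF and cAMP accumulation, with a stated time of 30 min; a higher number here means that more compound is needed for the effect, a lower number that less compound is needed. Compound 1 `O=C(O)c1csc([C@H]2CC[C@@H]3[C@@H](COc4ccccc4F)[C@H](O)C[C@@H]3O2)n1` gives 23 nM. Compound 2 `O=C(O)c1csc([C@H]2CC[C@@H]3[C@@H](COc4ccc(F)cc4)[C@H](O)C[C@@H]3O2)n1` gives 7 nM. Compound 3 `O=C(O)c1csc([C@H]2CC[C@@H]3[C@@H](CCCOc4ccccc4)[C@H](O)C[C@@H]3O2)n1` gives 10 nM, the second highest of the three numbers; its nearest neighbour is compound 2, and its furthest is compound 1.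

Compound 4 `O=C(O)c1csc([C@H]2CC[C@@H]3[C@@H](COc4ccccc4Cl)[C@H](O)C[C@@H]3O2)n1` has not yet been measured. It differs from compound 3 in one place: 2-chlorophenoxy in place of 2-phenoxyethyl on a saturated chain carbon bound to a saturated ring carbon. The change thus brings back a phenoxy group bearing a halogen at the 2-position of the ring, as compound 1 has, while removing the longer two-carbon chain of compound 3.

Going by the values given here, two measured steps bear on this. The step of a 2.3-fold lower number from compound 1 to compound 3 (0.36 log units; beyond the scatter) shows that going from 2-fluorophenoxy to 2-phenoxyethyl lowered the number; compound 4 reverses that direction of change, with chlorine in place of fluorine. The step of a 3.3-fold lower number from compound 1 to compound 2 (0.52 log units; beyond the scatter) shows that a 2-substituted phenoxy gave a higher number than a 4-substituted one. The step of a 1.4-fold higher number from compound 2 to compound 3 (0.15 log units; within the scatter) lies within the scatter and adds little. Compound 4 is therefore expected to sit nearer to compound 1 than to compound 3, with the estimated step of a 2.0-fold higher number from compound 3 to compound 4 (0.30 log units; within the scatter) being an increase of modest size. Compound 4 is estimated at 20 nM, within a range of 8 nM to 50 nM.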

Compound 4, half-maximal effective concentration: 3.3 nM
Compound 4: middle estimate off by 6.1-fold (0.78 log units), on the high side; measured number outside the range, below it.
By their numbers in this assay, from the lowest: compound 4; then compounds 2 and 3 (each within the scatter of the next); then compound 1.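

In this assay, the exchange of fluoro for chloro on an aromatic carbon, the only difference between the two compounds, gives a 7.0-fold lower number from compound 1 to compound 4 (0.84 log units; beyond the scatter), the largest step among the four compounds. The earlier compounds shown here had left 2-fluorophenoxy with the highest number, but this step shows that a halogen-bearing phenoxy group at this place does not in itself go with a high number, since the outcome changes with the halogen. The 2-chlorophenoxy group also gives a lower number than either of the other two groups, with a 2.1-fold lower number from compound 2 to compound 4 (0.33 log units; beyond the scatter) against the 4-fluorophenyl group on the oxygen and a 3.0-fold lower number from compound 3 to compound 4 (0.48 log units; beyond the scatter) against 2-phenoxyethyl, so that compound 4 has the lowest number of the four, and the longer chain of compound 3 is not needed for a low number.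

The data shown offer no measurement that accounts for the difference between chloro and fluoro here. The compounds shown also leave open whether bromo or methyl on the same ring would extend the trend, and whether chloro would give a similar step on the 4-fluorophenoxy pattern or on the phenyl ring of the 2-phenoxyethyl chain.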